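The source may report more compounds than this note shows. Statements on the series, on what has been measured and on what is new or still open speak of the compounds shown alone.

Measured so far in a functional assay on MCF7 cells (Homo sapiens) for antiproliferative activity, read by XTT assay, with a stated time of 72 h; on this read-out lower numbers stand for stronger inhibition and higher numbers for weaker inhibition:
- compound 1 `COc1ccc(-c2cc3ccccc3nc2/C=C/C(=O)c2ccccc2)cc1` gives 4040 nM
- compound 2 `COc1ccc(-c2cc3ccccc3nc2/C=C/C(=O)c2ccc(F)cc2)cc1` gives 5450 nM
- compound 3 `COc1ccc(-c2cc3ccccc3nc2/C=C/C(=O)c2ccc(Br)s2)cc1` gives 910 nM

Compound 3 has the lowest number of the three, and its distance to the other two is beyond the scatter. Compound 4 `COc1ccc(-c2cc3ccccc3nc2/C=C/C(=O)c2ccc[nH]2)cc1` differs from compound 3 in one place: 1H-pyrrol-2-yl in place of 5-bromothiophen-2-yl on a carbonyl carbon. Among the measured compounds shown here, two measured steps touch the same place, the ring on the carbonyl carbon. Going from compound 1 to compound 3 gave a 4.4-fold lower number from compound 1 to compound 3 (0.65 log units; beyond the scatter), and going from compound 2 to compound 3 gave a 6.0-fold lower number from compound 2 to compound 3 (0.78 log units; beyond the scatter). Both show that swapping the ring on the carbonyl carbon can move the number by a modest amount, and that the 5-bromothiophen-2-yl ring is the one that gave the low number. For the measured compounds named here, no measured compound carries a 1H-pyrrol-2-yl ring, so there is no direct guide for this ring. Taking the ring that lowered the number away, and putting in one that has not been tried, the expected outcome for compound 4 is a higher number than compound 3, estimated as a 2.7-fold higher number from compound 3 to compound 4 (0.44 log units; beyond the scatter), with the range wide enough to allow for no change at all. The estimated value for compound 4 is 2500 nM, between 800 nM and 8000 nM.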

Compound 4, half-maximal inhibitory concentration: > 10000 nM
Compound 4: a limit, no number; the forecaster's own chance of this, stated with the estimate: 10%; middle value at least 4.0-fold (0.60 log units) from the limit.
By their numbers in this assay, from the lowest: compound 3; then compounds 1 and 2 (each within the scatter of the next). At a limit, above all of these: compound 4.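

In this assay, compound 4 can be read only as a limit, not as a number, and it is the only compound shown at that limit: the limit of > 10000 nM in this assay, at which 1 of the 4 values shown sits. The ring on the carbonyl carbon now shows a large step, an at least 10-fold higher number from compound 3 to compound 4 (1.04 log units; beyond the scatter), where the earlier changes at this position were modest, and both rings in this step are five-membered aromatic rings with one hetero atom, so sharing that description does not keep the number low. The 1H-pyrrol-2-yl ring also separates from phenyl, with an at least 2.4-fold higher number from compound 1 to compound 4 (0.39 log units; beyond the scatter), whereas the comparison with 4-fluorophenyl, an at least 1.8-fold higher number from compound 2 to compound 4 (0.26 log units; that floor lies within the scatter), does not separate those two compounds.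

On these data alone, how far compound 4 lies past its limit stays unknown, and so does the full size of these steps. As far as these compounds go, the sulfur, the bromine and the ring hydrogen-bond donor all change in this single swap, so it remains open which of them matters, and a plain thiophen-2-yl ring or a pyrrole ring carrying a methyl group on its nitrogen would be needed to pull these changes apart.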